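Swapping tert-butyl for chloro on a poorly permeable series

The compounds below may be only part of what the source reports. "The series", "measured", "known", "first", "only" and "open" are said of these compounds alone.

Measured compounds:
- compound 1: `CNC(=O)c1cc(Oc2ccc3nc(Nc4cccc(C(C)(C)C)c4)ncc3c2)ccn1` — < 1 10^-6 cm/s
- compound 2: `CNC(=O)c1cc(Oc2ccc3nc(Nc4ccccc4Oc4ccccc4)ncc3c2)ccn1` — < 1 10^-6 cm/s

Compound 1 `CNC(=O)c1cc(Oc2ccc3nc(Nc4cccc(C(C)(C)C)c4)ncc3c2)ccn1` and compound 2 `CNC(=O)c1cc(Oc2ccc3nc(Nc4ccccc4Oc4ccccc4)ncc3c2)ccn1` share the same core and differ only in the aryl group attached to the amine. In an ADME assay on Caco-2 cells (Homo sapiens) for permeability, in the apical to basolateral direction (a higher number here means that the compound crosses the layer faster, a lower number that the compound crosses the layer more slowly), compound 1 gives < 1 10^-6 cm/s, which is a limit of the assay rather than a measured number. Compound 2 gives < 1 10^-6 cm/s in this assay, again a limit. Compound 1 therefore cannot be ranked against compound 2; both simply sit at the limit of < 1 10^-6 cm/s in this assay, at which 2 of the 2 values shown sit, so nothing in this assay distinguishes the two.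

Compound 3 `CNC(=O)c1cc(Oc2ccc3nc(Nc4cccc(Cl)c4)ncc3c2)ccn1` is the next compound to be measured. It differs from compound 1 by chloro in place of tert-butyl on an aromatic carbon, so the 3-(tert-butyl)phenyl becomes 3-chlorophenyl. Among the compounds with values here, no step between measured compounds exists here, so no measured change of the same kind can be consulted. Given that compound 1 sits at a limit of < 1 10^-6 cm/s, the step that the limit leaves unreadable from compound 1 to compound 3 is expected to be small, within the scatter. Compound 3 is therefore expected to give about 0.8 10^-6 cm/s, between 0.3 10^-6 cm/s and 3 10^-6 cm/s.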

Compound 3, apparent permeability: < 1 10^-6 cm/s
Compound 3 ended at the assay's limit (the forecaster's own chance of this, stated with the estimate: 60%); the middle value does not contradict the limit.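

Compound 1 and compound 3 both end at a limit of this assay rather than at a measured number, so the change from tert-butyl to chloro gives no readable step: the limit of < 1 10^-6 cm/s in this assay, at which 3 of the 3 values shown sit.

The compounds shown leave open how far each one truly lies from that limit, and whether any aryl group on the amine gives a readable value.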